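This account rests on a few compounds, and the source may have more. Where it says the series, first, only, none or still open, it means among the compounds named here.

Values measured in a functional assay on HEK293 cells (Homo sapiens) for cytotoxicity; a higher number here means that more compound is tolerated, a lower number that less compound is tolerated:
- Compound 1 `COc1ccc([C@H]2CC(=O)N(c3cccc(N(C)C)c3)C2)cc1OC1CCCC1`: > 10000 nM, a limit
- Compound 2 `COc1ccc([C@H]2CC(=O)N(c3cccc(NS(=O)(=O)c4cc(C)ccc4OC)c3)C2)cc1OC1CCCC1`: > 10000 nM, a limit
- Compound 3 `COc1ccc([C@H]2CC(=O)N(c3cccc(NS(=O)(=O)c4cccc(Cl)c4C)c3)C2)cc1OC1CCCC1`: > 10000 nM, a limit

Compound 3 has no actual number in this assay, only the limit > 10000 nM. It shares this position with the other two compounds, and the whole set reads as the limit of > 10000 nM in this assay, at which 3 of the 3 values shown sit.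

Compound 4 `COc1ccc([C@H]2CC(=O)N(c3cccc(NS(=O)(=O)c4cccc(Cl)c4)c3)C2)cc1OC1CCCC1` differs from compound 3 in a single place: hydrogen in place of methyl on an aromatic carbon. Put simply, hydrogen takes the place of methyl on an aromatic carbon, which turns 3-chloro-2-methylphenyl into 3-chlorophenyl.

Within the data shown here, two measured steps bear on this change. The closer one, at the same sulfonyl sulfur, is a step that the two limits leave unreadable from compound 2 to compound 3. The broader one is a step that the two limits leave unreadable from compound 1 to compound 3. Neither gives a size to carry forward, but both of these larger changes connect compounds that sit at the same limit. Removing one methyl is a smaller change, so no step beyond the usual scatter is expected, and no direction can be favoured. The expected step is a step that the limit leaves unreadable from compound 3 to compound 4. The estimate for compound 4 is 12000 nM, with an expected range from 6000 nM to 30000 nM, and the assay will most likely report only a limit again.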

Compound 4, half-maximal cytotoxic concentration: > 10000 nM
Compound 4 was reported as a limit; the forecaster's own chance of this, stated with the estimate: 85%; the middle value does not contradict the limit.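

In this assay compound 4 gives > 10000 nM as a limit and not a number. Among these compounds, no step among compound 1, compound 2, compound 3 and compound 4 can be read, because all four share one limit: the limit of > 10000 nM in this assay, at which 4 of the 4 values shown sit. The compounds shown leave open how much of each compound is tolerated, and whether swapping these groups changes that.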